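The source may hold more compounds than are shown below. What is called first, only, known or untested is meant among the compounds shown, and "the series" means these compounds.

In an ADME assay on HepG2 cells (Homo sapiens) for cytotoxicity, with a stated time of 72 h (a lower number here means that less compound is needed, a higher number that more compound is needed for the effect), compound 1 `O=C(Nc1ccc(O)c(-c2nc3ccccc3s2)c1)c1cc([N+](=O)[O-])ccc1Cl` gives only a limit of the assay, > 25000 nM. Compound 2 `COc1cc(Cl)c(C(=O)Nc2cccc(-c3nc4ccccc4s3)c2)cc1[N+](=O)[O-]` likewise gives only a limit there, > 25000 nM. Compound 2 therefore stands at the limit of > 25000 nM in this assay, at which 2 of the 2 values shown sit, and no number separates it from compound 1. Compound 3 `O=C(O)COc1cc(Cl)c(C(=O)Nc2cccc(-c3nc4ccccc4s3)c2)cc1[N+](=O)[O-]` differs from compound 2 by carboxy in place of hydrogen on a saturated chain carbon bound to an oxygen on an aromatic ring. Within the data shown here, no measured step matches this change, so its direction cannot be read from the data. Compound 3 is expected to remain near that limit in this assay, at an estimated 30000 nM with a range from 12000 nM to 80000 nM. The expected step that the limit leaves unreadable from compound 2 to compound 3 is estimated to stay within the scatter.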

Compound 3, half-maximal effective concentration: > 25000 nM
Compound 3 was reported as a limit; the forecaster's own chance of this, stated with the estimate: 80%; the middle value is on the limit's open side.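

No step can be read from compound 2 to compound 3, since neither gives a number in this assay, only a limit: the limit of > 25000 nM in this assay, at which 3 of the 3 values shown sit.

From the compounds shown here alone, whether carboxy in place of hydrogen changes anything here, and at what concentration any of the three compounds reaches the half-maximal effect, stays open.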